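A Heteroaryl Swap at the Benzylic Carbon of Compound 3

The compounds below may be only part of what the source reports. "The series", "measured", "known", "first", "only" and "open" are said of these compounds alone.

The three measured compounds, all read in a functional assay on HEK293 cells for agonist activity at Free fatty acid receptor 1 (Homo sapiens), read by fluorescence and calcium flux, with a stated time of 10 min (on this read-out higher numbers stand for an effect only at larger amounts of compound and lower numbers for an effect already at smaller amounts), are:

Compound 1, `CS(=O)(=O)CCCOc1ccc2c(c1)OC(COc1ccc(CCC(=O)O)c(F)c1)CC2`: 36300 nM
Compound 2, `COCCOc1ccc2c(c1)OC(COc1ccc(CCC(=O)O)c(F)c1)CC2`: 2370 nM
Compound 3, `CCOC(CC(=O)O)c1ccc(OCC2COc3ccc(Cl)cc3O2)cc1`: 640 nM

Among these three, compound 3 stands lowest, and both gaps are beyond the scatter: compound 2 is its nearest neighbour, compound 1 the furthest. Within the data shown here, the single step between compounds that differ in one place, a 15-fold lower number from compound 1 to compound 2 (1.19 log units; beyond the scatter), concerns a substituent on a saturated chain carbon two bonds from an oxygen on an aromatic ring, and it is large.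

Compound 4, `Cn1ccnc1C(CC(=O)O)c1ccc(OCC2COc3ccc(Cl)cc3O2)cc1`, has not yet been measured. It differs from compound 3 by 1-methyl-1H-imidazol-2-yl in place of ethoxy on a saturated chain carbon bound to an aromatic carbon and a saturated chain carbon. Among the measured compounds shown here, the change from compound 1 to compound 2 sits on a different part of the molecule and on a different kind of carbon, so it does not bear on this step; no measured pair shows what happens when the ethoxy at this saturated chain carbon is exchanged. With nothing to anchor a direction, the step is expected to stay within the scatter, a 1.3-fold lower number from compound 3 to compound 4 (0.11 log units; within the scatter). Compound 4 is therefore estimated at 500 nM in this assay, with a range from 150 nM to 2500 nM that allows for the missing precedent.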

Compound 4, half-maximal effective concentration: 5880 nM
For compound 4 the middle estimate is 12-fold (1.07 log units) below the measured one, outside the stated range (above it).
By their numbers in this assay, from the lowest: compound 3; then compound 2; then compound 4; then compound 1.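

Among these compounds, the exchange gives the first reading at this saturated chain carbon, bound to an aromatic carbon and a saturated chain carbon: in this assay the replacement of ethoxy by 1-methyl-1H-imidazol-2-yl gives a 9.2-fold higher number from compound 3 to compound 4 (0.96 log units; beyond the scatter) and so lies beyond the scatter, though it is classed as modest. The read-out therefore responds to what is carried at this carbon, and on this one pair the larger group, with 6 heavy atoms and one five-membered aromatic ring in place of 3 heavy atoms and no ring, goes with an effect only at larger amounts of compound. No measurement among the data given accounts for the direction or size of this step.

From the compounds shown here alone, it remains open whether the higher number goes with the ring as such, with its two nitrogens or with the methyl on the ring, and a phenyl ring, an unmethylated imidazole or a pyridine at this carbon would separate these readings. Also open, going by these compounds, is how a smaller or open-chain group, such as a methoxy, a hydroxyl or an amine, would read at this carbon on the same core.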